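A Methyl Step Carried From One Core to Another

A few compounds are considered here, and "the series" means these few. Any claim that something is new, unique, unknown or untested is made for them only; others in the source may bear on it.

Compound 1, `COn1c(-c2ccccc2)c(CO)c2cc(C#N)c(C#N)cc21`: 4990 nM
Compound 2, `COn1c(-c2ccc(C)cc2)c(CO)c2cc(C#N)c(C#N)cc21`: 5120 nM
Compound 3, `O=C(O)c1cc2cc(-c3ccccc3)n(O)c2cc1C(=O)O`: 23300 nM

All three were tested in an assay on isolated protein for inhibition of Amine oxidase [flavin-containing] A (Homo sapiens), read by fluorescence and spectrophotometry, with a stated time of 20 min; on this read-out lower numbers stand for stronger inhibition and higher numbers for weaker inhibition. Compound 1 and compound 2 share one core and differ in a single spot: methyl in place of hydrogen on an aromatic carbon. That change gave a 1.0-fold higher number from compound 1 to compound 2 (0.01 log units; within the scatter). Compound 3 is built on a different core; the difference between the two cores is not broken down here. In this assay compound 3 stands apart with the highest of the three numbers, beyond the scatter from compound 2 and from compound 1.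

Compound 4 `Cc1ccc(-c2cc3cc(C(=O)O)c(C(=O)O)cc3n2O)cc1` has not yet been measured. It differs from compound 3 in one spot: methyl in place of hydrogen on an aromatic carbon. Among the measured compounds shown here, this is the same change as the one made from compound 1 to compound 2: the same group leaves, the same group enters, and the place is described in the same words. For the measured compounds named here, the only guide for compound 4 is that earlier step, which lay within the scatter. For compound 4 the expected step is therefore a 1.0-fold higher number from compound 3 to compound 4 (0.01 log units; within the scatter). Whether a change behaves the same way on a different core cannot be read from these data, so the range is kept wide. The estimate for compound 4 in this assay is 24000 nM, with a likely span from 12000 nM to 48000 nM.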

Compound 4, half-maximal inhibitory concentration: > 100000 nM
Compound 4: no number, only a limit; the forecaster's own chance of this, stated with the estimate: 10%; at least 4.1-fold (0.61 log units) between middle value and limit.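

In this assay compound 4 gives > 100000 nM, which is a limit of the assay and not a number: the limit of > 100000 nM in this assay, at which 1 of the 4 values shown sits.

Even with only a limit, the step can be read: swapping phenyl for 4-methylphenyl on the core of compound 3 gave an at least 4.2-fold higher number from compound 3 to compound 4 (0.63 log units; beyond the scatter), whereas the same swap on the core of compound 1 gave a 1.0-fold higher number from compound 1 to compound 2 (0.01 log units; within the scatter), so in this small set the methyl change did not carry over unchanged from one core to the other: the same change on two cores in this assay, a 1.0-fold higher number (0.01 log units; within the scatter) from compound 1 to compound 2 and an at least 4.2-fold higher number (0.63 log units; beyond the scatter) from compound 3 to compound 4, at least 4.1-fold (0.62 log units) apart, beyond the scatter of two such steps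

The two cores differ in more than one place, so these data do not show which part of them sets the two steps apart, how large the step on the core of compound 3 really is, or whether the same would hold for other pairs in the series.

From the compounds shown here alone, it remains open whether an ethyl group or a chlorine atom in the same place, para to a large group, would follow the methyl on the core of compound 3 or behave differently. Going by these compounds, it is also open which of the groups that separate the two cores, such as the two carboxylic acids and the two nitriles, decides the outcome, a question that a core carrying one carboxylic acid and one nitrile could begin to answer.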